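Swapping pyrimidin-2-yl for pyrazin-2-yl on a sulfonamide

This account rests on a few compounds, and the source may have more. Where it says the series, first, only, none or still open, it means among the compounds named here.

Measured in a physicochemical assay for lipophilicity; on this read-out lower numbers stand for lower lipophilicity and higher numbers for higher lipophilicity:
- Compound 1 `O=S(=O)(Nc1ncccn1)c1ccc2c(c1)OCC[C@@H]2c1ccc(C(F)(F)F)cc1-c1ccc(F)nc1`: 2.8
- Compound 2 `Cn1nccc1-c1cc(C(F)(F)F)ccc1[C@H]1CCOc2cc(S(=O)(=O)Nc3nccs3)ccc21`: 2.2
- Compound 3 `Cn1nccc1-c1cc(C(F)(F)F)ccc1[C@H]1CCOc2cc(S(=O)(=O)Nc3ncccn3)ccc21`: 3.7

Compound 3 stands highest of the three at 3.7, clearly beyond the usual scatter of both others. The next structure, compound 4 `Cn1nccc1-c1cc(C(F)(F)F)ccc1[C@H]1CCOc2cc(S(=O)(=O)Nc3cnccn3)ccc21`, has pyrazin-2-yl in place of pyrimidin-2-yl on a sulfonamide nitrogen. The two have the same atoms, joined differently.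

Two measured steps offer some guidance. One, a number 0.90 log units higher from compound 1 to compound 3 (beyond the scatter), changes a different part of the molecule and bears only loosely on this swap. The other, a number 1.50 log units higher from compound 2 to compound 3 (beyond the scatter), acts on the same sulfonamide nitrogen and shows that a change there can matter greatly in this assay. Among the compounds with values here, no measured pair compares these two groups directly, so the direction remains uncertain. Compound 2, with another group on that nitrogen, sits lower at 2.2, which tips the expectation slightly downward. The expected change is small to modest, a number 0.30 log units lower from compound 3 to compound 4 (within the scatter). For compound 4 the estimated value is 3.4, with an expected range from 2.6 to 4.1.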

Compound 4, distribution coefficient: 1.8
Compound 4: the middle estimate sits 1.60 log units above what was measured, outside the stated range (below it).
By their numbers in this assay, from the lowest: compound 4; then compound 2; then compound 1; then compound 3.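

Pyrimidin-2-yl and pyrazin-2-yl have the same atoms and the same counts of hydrogen-bond donors and acceptors, yet on the sulfonamide nitrogen the swap gives a large change in this assay, with a number 1.90 log units lower from compound 3 to compound 4 (beyond the scatter). The earlier compounds shown here showed that a change of group here could matter, but not that rearranging the atoms within one ring could matter this much. Pyrazin-2-yl also falls under 1,3-thiazol-2-yl, with a number 0.40 log units lower from compound 2 to compound 4 (beyond the scatter), so among these three groups the order from high to low is pyrimidin-2-yl, 1,3-thiazol-2-yl, pyrazin-2-yl; no measurement at hand accounts for this order.

Going by these compounds, it remains open whether the swap would give a step of similar size with 6-fluoropyridin-3-yl in place of 1-methyl-1H-pyrazol-5-yl. Where a pyridin-2-yl or a plain phenyl on the sulfonamide nitrogen would fall in this order also remains open.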